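From ethoxy to methylamino on a carbonyl carbon

The source may hold more compounds than are shown below. What is called first, only, known or untested is meant among the compounds shown, and "the series" means these compounds.

compound 1 `CCNC(=O)c1noc(-c2cc(C(C)C)c(O)cc2O)c1-c1cc(CN)no1` - 84 nM
compound 2 `CCNC(=O)c1noc(-c2cc(C(C)C)c(O)cc2O)c1-c1cc(C(=O)OCC)no1` - "not determined" (no result reported)

In a functional assay on HCT-116 cells (Homo sapiens) for inhibition (a higher number here means a weaker inhibitor, a lower number a stronger inhibitor), compound 1 gives 84 nM and compound 2 stands as "not determined" (no result reported) with no single number to place it. Compound 3 `CCNC(=O)c1noc(-c2cc(C(C)C)c(O)cc2O)c1-c1cc(C(=O)NC)no1` keeps the core of compound 2 but has methylamino in place of ethoxy on a carbonyl carbon. Going by the values given here, with no number for compound 2, no step from it can be sized. Among the compounds with values here, the only guide is compound 1 at 84 nM as a reference, and compound 3 is expected near that level, perhaps slightly weaker, with no large jump. Compound 3 is estimated at 120 nM with 35 nM to 400 nM as the expected range.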

Compound 3, half-maximal inhibitory concentration: 124 nM
Compound 3: the middle estimate sits 1.0-fold (0.01 log units) below what was measured; low and high end bracket the measured number.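

In this assay, methylcarbamoyl in place of aminomethyl on this aromatic carbon gives a 1.5-fold higher number from compound 1 to compound 3 (0.17 log units; within the scatter), so the two groups cannot be told apart at this position, even though they are quite different groups. Going by these compounds, compound 2 has no number, so the step from ethoxy to methylamino cannot be read, and what the ester contributes stays unknown. Nothing measured here bears on why the two groups match. On these data alone, whether a carboxylic acid, a longer chain such as ethylcarbamoyl, or a tertiary amine such as dimethylaminomethyl would hold this level remains open.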